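Swapping chlorine for fluorine on the aryl ketone

A few compounds are considered here, and "the series" means these few. Any claim that something is new, unique, unknown or untested is made for them only; others in the source may bear on it.

Within the data shown here, compound 2 `COc1cc(-c2cc(/C=C/C(=O)c3ccc(Cl)c(Cl)c3)[nH]n2)cc(OC)c1OC` gives 66000 nM in a functional assay on SK-MEL-28 cells (Homo sapiens) for inhibition, read by sulforhodamine B assay, with a stated time of 48 h (on this read-out higher numbers stand for weaker inhibition of growth and lower numbers for stronger inhibition of growth), the highest of the two numbers measured so far. Its neighbour compound 1 `COc1cc(-c2cc(/C=C/C(=O)c3ccc(N)cc3)[nH]n2)cc(OC)c1OC` gives 4080 nM, and the step of a 16-fold higher number from compound 1 to compound 2 (1.21 log units; beyond the scatter) shows that changing the group on the carbonyl carbon can shift growth inhibition strongly. Compound 3 `COc1cc(-c2cc(/C=C/C(=O)c3ccc(F)c(F)c3)[nH]n2)cc(OC)c1OC` differs from compound 2 by 3,4-difluorophenyl in place of 3,4-dichlorophenyl on a carbonyl carbon. Among the measured compounds shown here, no measured step exchanges one halogen for another, so the only guide is that this position matters. Compound 3 is expected to give 40000 nM, with a range from 10000 nM to 150000 nM, a step of a 1.7-fold lower number from compound 2 to compound 3 (0.22 log units; within the scatter) that is estimated to stay close to compound 2.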

Compound 3, concentration for total growth inhibition: 28200 nM
For compound 3 the middle estimate is 1.4-fold (0.15 log units) above the measured one; the range from low to high includes it.
By their numbers in this assay, from the lowest: compound 1; then compound 3; then compound 2.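

In this assay the exchange of one halogen for another is enough to move the number, and growth inhibition becomes modestly stronger with the 3,4-difluorophenyl group (a 2.3-fold lower number from compound 2 to compound 3 (0.37 log units; beyond the scatter)). The 4-aminophenyl group still gives the strongest inhibition of the three compounds, and the gap to the difluoro compound remains clear (a 6.9-fold higher number from compound 1 to compound 3 (0.84 log units; beyond the scatter)). Nothing measured here explains why these groups differ.

Still open, as far as these compounds go, is how a phenyl ring carrying a single fluorine, a nitrile or a carboxylic acid would behave on this carbonyl carbon. Also open, from the compounds shown here alone, is whether a methylamino or dimethylamino group would match the 4-aminophenyl result.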